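Compound 2 and the group on its carbonyl carbon

A few compounds are considered here, and "the series" means these few. Any claim that something is new, unique, unknown or untested is made for them only; others in the source may bear on it.

Going by the values given here, in a functional assay on HepG2 cells (Homo sapiens) for antiproliferative activity, read by MTT assay, with a stated time of 48 h (on this read-out lower numbers stand for stronger inhibition and higher numbers for weaker inhibition), compound 1 `CCOC(=O)CN(C)C(=O)c1ccc(C(CC)(CC)c2ccc(OCCC(O)(CC)CC)c(C)c2)n1CC` reads 25300 nM while compound 2 `CCn1c(C(=O)N(C)CC(=O)O)ccc1C(CC)(CC)c1ccc(OCCC(O)(CC)CC)c(C)c1` reads 5710 nM as the lower of the two numbers so far. Among the compounds with values here, the one measured step is a 4.4-fold lower number from compound 1 to compound 2 (0.65 log units; beyond the scatter) with hydrogen in place of ethyl on an oxygen. Within the data shown here, compound 3 `CCn1c(C(=O)NC(CC(=O)O)C(=O)OC)ccc1C(CC)(CC)c1ccc(OCCC(O)(CC)CC)c(C)c1` has no measurement yet. Its change from compound 2 is a group of 10 heavy atoms (5 carbon, 1 nitrogen, 4 oxygen; no ring) in place of a group of 6 heavy atoms (3 carbon, 1 nitrogen, 2 oxygen; no ring), on a carbonyl carbon on a carbonyl carbon. Among the measured compounds shown here, no measured step covers this exchange, so the step to compound 2 from compound 1 gives only a rough sense of size, and the direction is uncertain. For the measured compounds named here, the expected step is a 1.6-fold higher number from compound 2 to compound 3 (0.20 log units; within the scatter) as a small move toward a higher number, smaller than the one measured step. The estimate in this assay for compound 3 is 9000 nM within an expected range from 3000 nM to 27000 nM at this stage.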

Compound 3, half-maximal inhibitory concentration: 10700 nM
Beside the measured number, compound 3's estimate is 1.2-fold (0.08 log units) below it, and the stated range covers the measured number.
By their numbers in this assay, from the lowest: compounds 2 and 3 (each within the scatter of the next); then compound 1.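

In this assay, replacing (carboxymethyl)(methyl)amino on the carbonyl carbon with a larger group with no ring gives a 1.9-fold higher number from compound 2 to compound 3 (0.27 log units; within the scatter), so this read-out does not separate the two groups despite the added heavy atoms, donors and acceptors. Replacing the ethyl ester group of compound 1 with the same larger group gives a 2.4-fold lower number from compound 1 to compound 3 (0.37 log units; beyond the scatter), in the same direction as a 4.4-fold lower number from compound 1 to compound 2 (0.65 log units; beyond the scatter), so both compounds carrying a carboxylic acid read lower than the ester compound 1, and neither goes against this among the three compounds. No supporting evidence bears on why these numbers fall as they do.

Going by these compounds, how an amine or a longer chain on the carbonyl carbon would read remains open. Also open, on these data alone, is whether a second carboxylic acid in place of the methyl ester of compound 3 would move the number beyond the scatter.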